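The source may hold more compounds than are shown below. What is called first, only, known or untested is meant among the compounds shown, and "the series" means these compounds.

Measured in a functional assay on A549 cells (Homo sapiens) for inhibition; on this read-out lower numbers stand for stronger inhibition and higher numbers for weaker inhibition:
- Compound 1 `O=C(CC(CC(=O)NC1Cc2ccccc2C1)c1ccccc1)NCCN1CCCCC1`: > 100000 nM
- Compound 2 `CCNCCNC(=O)CC(CC(=O)N(CC)C1Cc2ccccc2C1)c1ccccc1`: > 100000 nM
- Compound 3 `CCN(C(=O)CC(CC(=O)NCCN1CCCC1)c1ccccc1)C1Cc2ccccc2C1`: > 100000 nM

Each of these entries is a limit of the assay and not a number. Compound 3 stands at > 100000 nM, which is a limit, and no measured potency is therefore available as a starting point. The series shows only (the limit of > 100000 nM in this assay, at which 3 of the 3 values shown sit).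

Compound 4 `CCN(C(=O)CC(CC(=O)NCCN1CCCCC1)c1ccccc1)C1Cc2ccccc2C1` has not yet been measured. It carries piperidin-1-yl in place of pyrrolidin-1-yl on a saturated chain carbon, two bonds along the chain from an amide-type nitrogen.

Among the compounds with values here, the one measured step that bears on this change is a step that the two limits leave unreadable from compound 2 to compound 3, and it supplies no size. Compound 1 also carries piperidin-1-yl, and its result of > 100000 nM is likewise a limit. Nothing measured therefore points to a gain in this assay, and no step beyond the usual scatter is expected in either direction. The expected step is a number no higher from compound 3 to compound 4 (the limit leaves the size open). A further result at the limit is the most likely outcome. For compound 4 the estimated value is 100000 nM, with an expected range from 50000 nM to 200000 nM.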

Compound 4, half-maximal inhibitory concentration: 84500 nM
The estimate for compound 4 lay 1.2-fold (0.07 log units) above the measured number; the range from low to high includes it.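

In this assay, compound 4 is the only one of the compounds shown to return a number rather than a limit of the assay: the limit of > 100000 nM in this assay, at which 3 of the 4 values shown sit.

At this place, on a saturated chain carbon, two bonds along the chain from an amide-type nitrogen, piperidin-1-yl in place of pyrrolidin-1-yl gives an at least 1.1-fold lower number from compound 3 to compound 4 (0.07 log units; that floor lies within the scatter), and piperidin-1-yl in place of ethylamino gives an at least 1.1-fold lower number from compound 2 to compound 4 (0.07 log units; that floor lies within the scatter). Ethyl in place of hydrogen on an amide-type nitrogen, a change at a different place, gives an at least 1.1-fold lower number from compound 1 to compound 4 (0.07 log units; that floor lies within the scatter). Each of these steps is a floor set by a limit, so the result shows that the combination in compound 4 can be read in this assay, but not how large any of the three steps is.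

The compounds shown leave open whether another amine at this place, such as morpholin-4-yl or azepan-1-yl, would give a number in this assay. They also leave open whether a propyl group in place of the ethyl on the amide-type nitrogen would keep the value readable.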